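Amino in place of chloro on a shared core

The source may report more compounds than this note shows. Statements on the series, on what has been measured and on what is new or still open speak of the compounds shown alone.

Measured compounds:
compound 1 `Nc1nc(Cl)c2ncn(Cc3ccc(CCl)cc3)c2n1`: 15000 nM
compound 2 `ClCc1cccc(Cn2cnc3c(Cl)nc(Cl)nc32)c1`: 3090 nM
compound 3 `ClCc1ccc(Cn2cnc3c(Cl)nc(Cl)nc32)cc1`: 3630 nM

In a functional assay on HCT-116 cells (Homo sapiens) for cytotoxicity, read by sulforhodamine B assay, with a stated time of 48 h (on this read-out lower numbers stand for stronger inhibition of growth and higher numbers for weaker inhibition of growth), compound 3 gives 3630 nM and compound 1 gives 15000 nM. The change between them is amino in place of chloro on an aromatic carbon, and it made the step of a 4.1-fold higher number from compound 3 to compound 1 (0.62 log units; beyond the scatter). Compound 2 and compound 3 have the same atoms joined differently; the difference between the two cores is not broken down here. In this assay compound 2 gives 3090 nM. Compound 4 `Nc1nc(Cl)c2ncn(Cc3cccc(CCl)c3)c2n1` is not yet measured; it differs from compound 2 by amino in place of chloro on an aromatic carbon, the same change as seen between compound 3 and compound 1. Among the measured compounds shown here, the step is expected to be a 4.0-fold higher number from compound 2 to compound 4 (0.61 log units; beyond the scatter), resting on a 4.1-fold higher number from compound 3 to compound 1 (0.62 log units; beyond the scatter) as the only earlier instance of this change. Compound 4 is therefore expected at 12500 nM, with a range from 5000 nM to 30000 nM.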

Compound 4, concentration for total growth inhibition: 3890 nM
Beside the measured number, compound 4's estimate is 3.2-fold (0.51 log units) above it, and the stated range ends above it.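

In this assay, amino in place of chloro on an aromatic carbon gives a 1.3-fold higher number from compound 2 to compound 4 (0.10 log units; within the scatter), so this instance shows no effect beyond the scatter. Set beside the earlier instance, the change does not carry from one core to the other at a fixed size: the same change on two cores in this assay, a 4.1-fold higher number (0.62 log units; beyond the scatter) from compound 3 to compound 1 and a 1.3-fold higher number (0.10 log units; within the scatter) from compound 2 to compound 4, 3.3-fold (0.52 log units) apart, beyond the scatter of two such steps. Two instances show that the size of the step differed between these cores, but they do not show which difference between the cores accounts for it, nor how the step would behave on a further core.

Still open, as far as these compounds go, is whether a methylamino or a methoxy group in place of chloro at the same carbon would follow either step. Also open, from the compounds shown here alone, is how a hydroxymethyl group in place of the chloromethyl group would read on either core.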